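This account rests on a few compounds, and the source may have more. Where it says the series, first, only, none or still open, it means among the compounds named here.

Working notes on the series. Compound 1 `COc1cc(-c2cc(/C=C/C(=O)c3ccc(N)cc3)[nH]n2)cc(OC)c1OC` gives -40% in a functional assay on SW-620 cells (Homo sapiens) for cytotoxicity, read by sulforhodamine B assay, with a stated time of 48 h, tested at 100 uM; on this read-out higher numbers stand for a weaker effect at the one concentration tested and lower numbers for a stronger effect. Compound 2 `COc1ccc(C(=O)/C=C/c2cc(-c3cc(OC)c(OC)c(OC)c3)n[nH]2)cc1OC` gives -67% in this assay, and compound 3 `COc1ccc(C(=O)/C=C/c2cc(-c3cc(OC)c(OC)c(OC)c3)n[nH]2)cc1` gives -39% in this assay. Compound 2 stands lowest of the three numbers: the step of a number 27 percentage points lower from compound 1 to compound 2 (beyond the scatter) and the step of a number 28 percentage points higher from compound 2 to compound 3 (beyond the scatter) are both beyond the scatter, whereas a number 1 percentage points higher from compound 1 to compound 3 (within the scatter), so the two neighbours of compound 2 cannot be ordered against each other.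

Compound 4 `COc1cc(C(=O)/C=C/c2cc(-c3cc(OC)c(OC)c(OC)c3)n[nH]2)cc(OC)c1OC` is not yet measured. It differs from compound 2 in one place: methoxy in place of hydrogen on an aromatic carbon. The new group sits on an aromatic carbon of a six-membered aromatic ring of carbon only, ortho to a methoxy group, meta to a large group and meta to a methoxy group. The measured step that bears on this is the reverse of a number 28 percentage points higher from compound 2 to compound 3 (beyond the scatter), where taking a methoxy off that same ring raised the number by a modest amount. Adding a further methoxy is therefore expected to move this assay downward again, probably by less than that earlier step, and the expected change is a number 7 percentage points lower from compound 2 to compound 4 (within the scatter). For compound 4 the estimate is -74%, with a range from -92% to -52%.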

Compound 4, a percentage reported as activity, at one concentration (the size of the read-out at that concentration, not a potency): -95%
Estimate against measurement, compound 4: 21 percentage points above; measured number outside the range, below it.
By their numbers in this assay, from the lowest: compound 4; then compound 2; then compounds 1 and 3 (each within the scatter of the next).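

In this assay, the methoxy that enters on this aromatic carbon, ortho to a methoxy group, meta to a large group and meta to a methoxy group, gives a number 28 percentage points lower from compound 2 to compound 4 (beyond the scatter), so the downward movement continues on a ring that already carries two methoxy groups. The earlier compounds shown here showed only the removal of a methoxy from this ring, a number 28 percentage points higher from compound 2 to compound 3 (beyond the scatter); the new step adds a second methoxy change of the same printed size and does not taper off, which is what the earlier pair could not show. No measurement in hand accounts for this step, so the series gives the size of the change without any explanation of it.

From the compounds shown here alone, what stays open is whether the step belongs to methoxy itself or would also appear with hydroxy, ethoxy or fluorine on the same aromatic carbon. Going by these compounds, it is also open whether an amino group or a longer alkoxy chain at this place would move the number in the same direction, and all of these readings stand at one concentration, so they describe the size of the effect there and not a potency.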